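The compounds below may be only part of what the source reports. "The series", "measured", "known", "first", "only" and "open" are said of these compounds alone.

Compound 1 `O=C(O)C(Sc1nc(Cl)cc(Nc2ccc3ncccc3c2)n1)c1ccccc1`: "not active" (no number reported)
Compound 2 `CCOC(=O)CSc1nc(Cl)cc(Nc2cccc3c2CCC3)n1`: 65.2%
Compound 3 `CCCCC(Sc1nc(Cl)cc(Nc2ccc3ncccc3c2)n1)C(=O)O`: "not active" (no number reported)

In an assay for inhibition of Polyunsaturated fatty acid 5-lipoxygenase (Homo sapiens), tested at 1 uM (on this read-out lower numbers stand for a stronger effect and higher numbers for a weaker effect at the one concentration tested), compound 2 stands alone with a number; compound 1 and compound 3 have entries without one. Compound 4 `O=C(O)CSc1nc(Cl)cc(Nc2cccc3c2CCC3)n1` is not yet measured. From compound 2 to compound 4 the change is hydrogen in place of ethyl on an oxygen next to a carbonyl group. Among the compounds with values here, no measured pair shows this step by itself, so its size is not known from the set. Compound 1 and compound 3 carry the carboxy and are reported without a number, but both also differ from compound 2 elsewhere, so they give no direct guide. The step is expected to run toward a weaker effect, a number 14.8 percentage points higher from compound 2 to compound 4 (beyond the scatter), of modest size, with a fair chance that only a non-numeric entry results. Compound 4 is expected to give 80%, in a range from 55% to 100%.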

Compound 4, a percentage reported as activity, at one concentration (the size of the read-out at that concentration, not a potency): 71.1%
Compound 4: the middle estimate sits 8.9 percentage points above what was measured; the measured number falls inside the stated range.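

In this assay, the change from ethyl to hydrogen on an oxygen next to a carbonyl group reads as a number 5.9 percentage points higher from compound 2 to compound 4 (within the scatter), so ethoxycarbonyl and carboxy cannot be told apart on this core. A carboxy on this core therefore still gives a number, which compound 1 and compound 3 could not show. No measurement at hand offers an explanation for this result.

From the compounds shown here alone, whether a primary amide or a methyl ester at this place would read the same stays open. So does the size of this step on the core of compound 1.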